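A few compounds are considered here, and "the series" means these few. Any claim that something is new, unique, unknown or untested is made for them only; others in the source may bear on it.

The measured compounds in a functional assay on A549 cells (Homo sapiens) for antiproliferative activity, read by MTT assay, with a stated time of 72 h; on this read-out lower numbers stand for stronger inhibition and higher numbers for weaker inhibition:
compound 1 `CN(C(=O)c1ccc(Cl)cc1)c1ccc2[nH]c(-c3n[nH]c4ccccc34)cc2n1`, 2220 nM
compound 2 `CN(C(=O)c1ccc(Br)cc1)c1ccc2[nH]c(-c3n[nH]c4ccccc34)cc2n1`, 4250 nM
compound 3 `CN(c1ccc2[nH]c(-c3n[nH]c4ccccc34)cc2n1)S(=O)(=O)c1ccc(Cl)cc1`, 18200 nM

Compound 3 gives the highest of the three numbers in this assay: an 8.2-fold higher number from compound 1 to compound 3 (0.91 log units; beyond the scatter) and a 4.3-fold higher number from compound 2 to compound 3 (0.63 log units; beyond the scatter), both beyond the scatter. Compound 4 `CN(c1ccc2[nH]c(-c3n[nH]c4ccccc34)cc2n1)S(=O)(=O)c1ccc(OC(F)(F)F)cc1` differs from compound 3 by trifluoromethoxy in place of chloro on an aromatic carbon. Going by the values given here, no measured step exchanges these two groups. The nearest comparison is a 1.9-fold higher number from compound 1 to compound 2 (0.28 log units; within the scatter), an exchange of one halogen for another on the aryl of an amide rather than of a sulfonyl, and within the scatter. On that thin basis no step beyond the scatter is expected in this assay in either direction. The expected step is a 1.0-fold lower number from compound 3 to compound 4 (0.00 log units; within the scatter). Compound 4 is therefore estimated at 18000 nM, in the range 7000 nM to 45000 nM.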

Compound 4, half-maximal inhibitory concentration: 8000 nM
Compound 4: the middle estimate sits 2.3-fold (0.35 log units) above what was measured; the range from low to high includes it.
By their numbers in this assay, from the lowest: compounds 1, 2 and 4 (each within the scatter of the next, the first and the last beyond it); then compound 3.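

In this assay, the substituent on the aryl of the sulfonyl can shift the number: trifluoromethoxy in place of chloro gives a 2.3-fold lower number from compound 3 to compound 4 (0.36 log units; beyond the scatter), whereas the halogen exchange on the aryl of the amide, a 1.9-fold higher number from compound 1 to compound 2 (0.28 log units; within the scatter), stayed within the scatter. The entering group has five heavy atoms against one and brings a hydrogen-bond acceptor, yet the number does not rise. Nothing measured here accounts for this step. From the compounds shown here alone, it remains open whether the same exchange would act alike on the amide of compound 1, and how an amine or a carboxylic acid would read at this position.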